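The compounds below may be only part of what the source reports. "The series", "measured", "known", "first", "only" and "open" are said of these compounds alone.

Compound 1 `Cc1cc(C)c2sc(NC(=O)c3ccc(C#N)cc3)nc2c1`: 0.62 ug/mL
Compound 2 `COc1ccc(C(=O)Nc2nc3c(OC)cccc3s2)cc1`: 3.46 ug/mL
Compound 3 `COc1ccc(C(=O)Nc2nc3cc(OC)ccc3s2)cc1`: > 10 ug/mL (a limit)

Three compounds sharing the same core were tested in a functional assay on NUGC-3 cells (Homo sapiens) for antiproliferative activity, read by sulforhodamine B assay; on this read-out higher numbers stand for weaker inhibition of growth and lower numbers for stronger inhibition of growth. Compound 1 gives 0.62 ug/mL in this assay. Compound 2 gives 3.46 ug/mL in this assay, the higher of the two numbers, with compound 1 standing clearly lower, beyond the scatter. Compound 3 reached only the limit of this assay, as marked by the limit of > 10 ug/mL in this assay, at which 1 of the 3 values shown sits, so no number is known for it.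

The step of interest leads from compound 2 to compound 4 `COc1cccc2sc(NC(=O)c3ccc([N+](=O)[O-])cc3)nc12`, which differs in one place: nitro in place of methoxy on an aromatic carbon. Within the data shown here, no measured pair shows this exact exchange, so its effect cannot be read directly from the data. Compound 4 is expected to give 1.5 ug/mL in this assay, with a range from 0.5 ug/mL to 5 ug/mL. That estimate corresponds to an expected step of a 2.3-fold lower number from compound 2 to compound 4 (0.36 log units; beyond the scatter), a modest move toward stronger inhibition of growth, not far beyond the scatter.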

Compound 4, concentration for 50% growth inhibition: > 10 ug/mL
Compound 4 gave a limit, no number; the forecaster's own chance of this, stated with the estimate: 10%; middle value at least 6.6-fold (0.82 log units) away from the limit.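

In this assay, putting nitro in place of methoxy on this aromatic carbon, para to a large group, gives an at least 2.8-fold higher number from compound 2 to compound 4 (0.46 log units; beyond the scatter). Among these compounds, this is the first direct sign that the group at this position matters for growth inhibition, and this exchange weakens it. Compound 4 gives > 10 ug/mL, which is a limit of the assay and not a number, so the step has a smallest possible size but no known true size, and compound 4 joins the compounds without a number: the limit of > 10 ug/mL in this assay, at which 2 of the 4 values shown sit.

Going by these compounds, what remains open is whether the loss belongs to nitro alone or whether methoxy is unusually well suited to this position. An amine, a hydroxyl group or a chlorine atom on the same carbon could help to separate these two readings.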